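Swapping the amine-side ring in a sulfonamide series

The source may report more compounds than this note shows. Statements on the series, on what has been measured and on what is new or still open speak of the compounds shown alone.

Three sulfonamides have been measured in a functional assay on MIA PaCa-2 cells (Homo sapiens) for inhibition, read by MTT assay, with a stated time of 72 h; a higher number here means a weaker inhibitor of growth, a lower number a stronger inhibitor of growth. Compound 1 `O=[N+]([O-])c1ccc(S(=O)(=O)NCCCCCCNCc2ccc(Br)cc2)cc1` gives 9800 nM in this assay, and compound 2 `COc1ccc(S(=O)(=O)NCCCCCCNCc2ccc(Br)cc2)cc1` gives 13000 nM. Going by the values given here, the single measured step, a 1.3-fold higher number from compound 1 to compound 2 (0.12 log units; within the scatter), shows that the aryl substituent on the sulfonyl side hardly moved the number. Compound 3 `O=S(=O)(NCCCNCC1COc2ccccc2O1)c1cc(C(F)(F)F)cc(C(F)(F)F)c1` stands lowest of the three with 2600 nM, its gap to compound 1 and to compound 2 lying beyond the scatter.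

Compound 4 `O=S(=O)(NCCCNCc1cccc(Cl)c1)c1cc(C(F)(F)F)cc(C(F)(F)F)c1` is not yet measured. It differs from compound 3 by 3-chlorophenyl in place of 2,3-dihydro-1,4-benzodioxin-2-yl on a saturated chain carbon bound to an amine nitrogen, so the sulfonamide and the three-carbon chain of compound 3 are kept while the group on the amine side becomes a 3-chlorobenzyl. Among the compounds with values here, no measured pair in this set changes the amine-side group, so the only step on record, a 1.3-fold higher number from compound 1 to compound 2 (0.12 log units; within the scatter), concerns a different part of the molecule and does not tell how this change will read. Compounds 1 and 2 carry a benzyl on the amine nitrogen and give higher numbers than compound 3, but they also differ in the chain and the sulfonyl aryl, so no direction can be drawn from them.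

The step of a 1.3-fold higher number from compound 3 to compound 4 (0.13 log units; within the scatter) is therefore expected to stay close to the scatter. Compound 4 is estimated at 3500 nM, with a range from 1200 nM to 10000 nM.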

Compound 4, concentration for 50% growth inhibition: 4400 nM
For compound 4 the middle estimate is 1.3-fold (0.10 log units) below the measured one; the measured number falls inside the stated range.
By their numbers in this assay, from the lowest: compounds 3 and 4 (each within the scatter of the next); then compounds 1 and 2 (each within the scatter of the next).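

In this assay, going by these compounds alone, the group on the amine side could be exchanged with a 1.7-fold higher number from compound 3 to compound 4 (0.23 log units; within the scatter) as the only change in the reading, so this first step at this place stays inside the scatter. The exchange is not small in structure: 2,3-dihydro-1,4-benzodioxin-2-yl, with 10 heavy atoms, a six-membered non-aromatic ring and 2 hydrogen-bond acceptors, gives way to 3-chlorophenyl, with 7 heavy atoms, no such ring and no acceptors, yet the two compounds are not separated by their numbers. No measured evidence on record bears on this result.

Still open, from the compounds shown here alone, is how the reading behaves with other groups on this saturated chain carbon bound to an amine nitrogen, such as an unsubstituted phenyl, a pyridine ring or a carboxylic acid, and whether a bromine in place of the chlorine would read alike. Compound 1 and compound 2 differ from compound 4 in the chain, the sulfonyl aryl and the halogen together, so a series that changes only the chain, for example a longer chain on the core of compound 4, would be needed to place that part of the molecule.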